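The source may hold more compounds than are shown below. What is called first, only, known or untested is meant among the compounds shown, and "the series" means these compounds.

The measured compounds are:

compound 1, `Cc1cc(C)cc(NC(=O)NCCNS(=O)(=O)c2ccc(-c3ccccc3Oc3ccc([N+](=O)[O-])c([N+](=O)[O-])c3)s2)c1`, which gives 9100 nM in a functional assay on HL-60 cells (Homo sapiens) for inhibition, read by CCK-8 assay, with a stated time of 48 h; on this read-out lower numbers stand for stronger inhibition and higher numbers for weaker inhibition;
compound 2, `O=C(NCCNS(=O)(=O)c1ccc(-c2ccccc2Oc2ccc([N+](=O)[O-])c([N+](=O)[O-])c2)s1)Nc1cc(Cl)cc(Cl)c1`, which gives 2300 nM in this assay;
compound 3, `Cc1cc(C)cc(NC(=O)NCCNS(=O)(=O)c2ccc(-c3ccccc3OCc3ccccc3)s2)c1`, which gives 2200 nM in this assay.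

Compound 2 differs from compound 1 by 3,5-dichlorophenyl in place of 3,5-dimethylphenyl on an amide-type nitrogen, and this change brought a 4.0-fold lower number from compound 1 to compound 2 (0.60 log units; beyond the scatter). Compound 3 differs from compound 1 at another place, by benzyl in place of 3,4-dinitrophenyl on an oxygen on an aromatic ring, and that change brought a 4.1-fold lower number from compound 1 to compound 3 (0.62 log units; beyond the scatter). The values of compound 2 and compound 3 lie within the usual scatter of each other, so nothing separates them in this assay.

Compound 4, `O=C(NCCNS(=O)(=O)c1ccc(-c2ccccc2OCc2ccccc2)s1)Nc1cc(Cl)cc(Cl)c1`, has not yet been measured. It differs from compound 3 by 3,5-dichlorophenyl in place of 3,5-dimethylphenyl on an amide-type nitrogen, the same change that was made from compound 1 to compound 2, at a place described in the same words. The two cores on which the change is made differ by benzyl in place of 3,4-dinitrophenyl on an oxygen on an aromatic ring.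

The change has been seen once, where it gave a 4.0-fold lower number from compound 1 to compound 2 (0.60 log units; beyond the scatter). On the core of compound 3 a step of roughly a 2.2-fold lower number from compound 3 to compound 4 (0.34 log units; beyond the scatter) is expected, resting on that single earlier step and on the value of compound 3, 2200 nM, with some allowance for the change having been observed only once. Compound 4 is therefore estimated at 1000 nM in this assay, with a likely range from 350 nM to 3000 nM.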

Compound 4, half-maximal inhibitory concentration: 11700 nM
Compound 4: the middle estimate sits 12-fold (1.07 log units) below what was measured; measured number outside the range, above it.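

In this assay the exchange of 3,5-dimethylphenyl for 3,5-dichlorophenyl on the amide-type nitrogen did not carry over from one core to the other: on the benzyl-bearing core it gave a 5.3-fold higher number from compound 3 to compound 4 (0.73 log units; beyond the scatter), against the opposite direction on the core with 3,4-dinitrophenyl: the same change on two cores in this assay, a 4.0-fold lower number (0.60 log units; beyond the scatter) from compound 1 to compound 2 and a 5.3-fold higher number (0.73 log units; beyond the scatter) from compound 3 to compound 4, 21-fold (1.32 log units) apart, beyond the scatter of two such steps. The exchange on the oxygen on an aromatic ring reversed in the same way, with benzyl in place of 3,4-dinitrophenyl giving a 5.1-fold higher number from compound 2 to compound 4 (0.71 log units; beyond the scatter) on the core with 3,5-dichlorophenyl, and not the lower number seen on the core with 3,5-dimethylphenyl: the same change on two cores in this assay, a 4.1-fold lower number (0.62 log units; beyond the scatter) from compound 1 to compound 3 and a 5.1-fold higher number (0.71 log units; beyond the scatter) from compound 2 to compound 4, 21-fold (1.32 log units) apart, beyond the scatter of two such steps. In these compounds the outcome of each change therefore depends on what stands at the other place, so the two changes cannot be treated as independent, but this rests on a single set of four compounds and shows neither why the direction reverses nor what either change would do on any further core.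

The compounds shown leave open whether an unsubstituted phenyl or a 3,5-dimethoxyphenyl on the amide-type nitrogen would follow the dimethylphenyl or the dichlorophenyl compounds. From the compounds shown here alone, it also remains open how a methyl or a single nitrophenyl on the oxygen would behave on either core.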